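The source may report more compounds than this note shows. Statements on the series, on what has been measured and on what is new or still open speak of the compounds shown alone.

Notes on the series. Compound 1 `Cc1ccc(OCC(=O)N(CCO)Cc2cccs2)cc1` is the weaker of the two compounds with numbers in hand: in an assay on HEK293 cells for agonist activity at transient receptor potential cation channel subfamily M member 8 (Homo sapiens), read by fluorescence and calcium flux, with a stated time of 15 min (on this read-out higher numbers stand for an effect only at larger amounts of compound and lower numbers for an effect already at smaller amounts), compound 1 gives 900 nM, the highest of the two values recorded. Among the measured compounds shown here, compound 2 `CCN(Cc1cccs1)C(=O)COc1ccc2c(c1)COC2` in this assay gives 61 nM, which sits well clear of compound 1 beyond the usual scatter; the two structures differ in several places, so these numbers are taken only as they stand, with no single step read out of them.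

The next compound, compound 3 `Cc1ccc(OCC(=O)N(Cc2cccs2)c2nccn2C)cc1`, carries one change relative to compound 1, (1-methyl-1H-imidazol-2-yl in place of 2-hydroxyethyl on an amide-type nitrogen). For the measured compounds named here, nothing measured so far probes this change, so the size of the step is open. The step in this assay is expected to be small, a 1.5-fold lower number from compound 1 to compound 3 (0.18 log units; within the scatter), in the direction of a lower number but not clearly beyond the scatter. Compound 3 in this assay is therefore expected to give about 600 nM, within a range from 150 nM to 2500 nM.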

Compound 3, half-maximal effective concentration: 1790 nM
For compound 3 the middle estimate is 3.0-fold (0.47 log units) below the measured one; the measured number falls inside the stated range.
By their numbers in this assay, from the lowest: compound 2; then compounds 1 and 3 (each within the scatter of the next).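

In this assay, among the compounds shown here, the first single-place step at this nitrogen is a 2.0-fold higher number from compound 1 to compound 3 (0.30 log units; within the scatter), and it lies within the scatter. For this pair, then, 1-methyl-1H-imidazol-2-yl, a five-membered aromatic ring with no hydrogen-bond donor, can stand on the amide-type nitrogen in place of 2-hydroxyethyl, a ringless group with a hydrogen-bond donor, with no difference that can be told from repeat-measurement noise. Nothing at hand bears on the reason for this outcome.

From the compounds shown here alone, whether other groups on this nitrogen, such as a propyl chain, a phenyl ring or a 2-aminoethyl chain, would also stay within the scatter of compound 1 remains open. Also open, going by these compounds, is whether 1-methyl-1H-imidazol-2-yl would give a similar step on the core of compound 2.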